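Moving the Nitrile from 4-Cyanophenyl to 3-Cyanophenyl

The source may hold more compounds than are shown below. What is called first, only, known or untested is meant among the compounds shown, and "the series" means these compounds.

In a functional assay on HepG2 cells (Homo sapiens) for antiproliferative activity, read by MTT assay, with a stated time of 72 h (a lower number here means a stronger inhibitor, a higher number a weaker inhibitor), compound 1 (`COc1cc2c(Nc3ccc(C#N)cc3)ncnc2cc1OCCCN1CCC(C)CC1`) gives 32100 nM, compound 2 (`COc1cc2c(Nc3ccc(C#N)cc3)ncnc2cc1OCCCN1CCC(CO)CC1`) gives 61800 nM and compound 3 (`CCOC(=O)C1CCN(CCCOc2cc3ncnc(Nc4ccc(C#N)cc4)c3cc2OC)CC1`) gives 57700 nM. Compound 1 therefore stands within the scatter of both neighbours, with a 1.9-fold higher number from compound 1 to compound 2 (0.28 log units; within the scatter) and a 1.8-fold higher number from compound 1 to compound 3 (0.25 log units; within the scatter). The remaining pair tells the same story, with a 1.1-fold lower number from compound 2 to compound 3 (0.03 log units; within the scatter).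

Compound 4 (`COc1cc2c(Nc3cccc(C#N)c3)ncnc2cc1OCCCN1CCC(C)CC1`) differs from compound 1 by one change, 3-cyanophenyl in place of 4-cyanophenyl on a nitrogen on an aromatic ring.

None of the three measured steps touches the cyanophenyl group. Each exchanges a group on a saturated carbon, so they offer no direct measure of this change and only show a series that has not yet moved beyond the scatter. With nothing pointing either way, no shift beyond the scatter is expected, and the expected step is a 1.2-fold higher number from compound 1 to compound 4 (0.07 log units; within the scatter). In this assay the estimate for compound 4 is 38000 nM, with an expected range of 15000 nM to 85000 nM.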

Compound 4, half-maximal inhibitory concentration: 18200 nM
Compound 4: middle estimate off by 2.1-fold (0.32 log units), on the high side; the range from low to high includes it.
By their numbers in this assay, from the lowest: compounds 4, 1, 3 and 2 (each within the scatter of the next, the first and the last beyond it).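

Going by these compounds alone, this swap is the first step that touches the group on the nitrogen on an aromatic ring rather than a group on a saturated carbon, and it gives a 1.8-fold lower number from compound 1 to compound 4 (0.25 log units; within the scatter) in this assay. The two compounds have the same atoms, joined differently, so the step isolates where the nitrile sits on the phenyl ring, and with methyl on the saturated ring, 3-cyanophenyl and 4-cyanophenyl cannot be told apart in this read-out. Nothing available bears on what lies behind this result.

On these data alone, whether 3-cyanophenyl behaves the same way with hydroxymethyl or ethoxycarbonyl on the saturated ring remains open. So does the outcome of placing a carboxylic acid or an amide where the nitrile stands.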